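Amide variation on the shared core: furan-2-yl replaces 4-nitrophenyl

The source may report more compounds than this note shows. Statements on the series, on what has been measured and on what is new or still open speak of the compounds shown alone.

Two members of the series carry a measured number in a functional assay on HCT-116 cells (Homo sapiens) for antiproliferative activity, read by MTT assay, with a stated time of 72 h; a lower number here means a stronger inhibitor, a higher number a weaker inhibitor. Compound 1 `CN(C(=O)c1ccccc1)c1ccc2[nH]c(-c3n[nH]c4ccccc34)cc2n1` gives 10600 nM in this assay, and compound 2 `CN(C(=O)c1ccc([N+](=O)[O-])cc1)c1ccc2[nH]c(-c3n[nH]c4ccccc34)cc2n1` gives 19900 nM. For the measured compounds named here, compound 2 has the higher of the two numbers, but the only step so far, a 1.9-fold higher number from compound 1 to compound 2 (0.27 log units; within the scatter), lies within the scatter, so the two are not separated. Compound 3 `CN(C(=O)c1ccco1)c1ccc2[nH]c(-c3n[nH]c4ccccc34)cc2n1` has not yet been measured; it differs from compound 2 by furan-2-yl in place of 4-nitrophenyl on a carbonyl carbon. Going by the values given here, no measured step exchanges one ring for another on the carbonyl carbon; the single step that touches that aryl group, a 1.9-fold higher number from compound 1 to compound 2 (0.27 log units; within the scatter), changed nothing beyond the scatter. The expectation for compound 3 in this assay is therefore a number close to that of compound 2, with a 1.5-fold lower number from compound 2 to compound 3 (0.18 log units; within the scatter) expected to fall within the scatter. Compound 3 is estimated at 13000 nM, with a range from 4000 nM to 40000 nM.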

Compound 3, half-maximal inhibitory concentration: 30000 nM
Estimate against measurement, compound 3: 2.3-fold (0.36 log units) below, within the range that was stated.
By their numbers in this assay, from the lowest: compounds 1, 2 and 3 (each within the scatter of the next, the first and the last beyond it).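

A ring-for-ring exchange on the carbonyl carbon now has a measured step: a 1.5-fold higher number from compound 2 to compound 3 (0.18 log units; within the scatter) in this assay does not separate furan-2-yl from 4-nitrophenyl at this place. Furan-2-yl in place of phenyl gives the first change at this position that passes the scatter, with a 2.8-fold higher number from compound 1 to compound 3 (0.45 log units; beyond the scatter) marking a modest weakening in this assay that rests on this one pair. Nothing available accounts for this difference between the rings.

On these data alone, whether any group on the carbonyl carbon gives a number clearly lower than that of the phenyl amide remains open, for example a piperidine ring or a longer alkyl chain in place of the ring. Also open, as far as these compounds go, is whether an amine or a carboxylic acid on the phenyl ring would move the number beyond the scatter.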